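From 3-bromopropyl to cyanomethyl on the shared core

The source may report more compounds than this note shows. Statements on the series, on what has been measured and on what is new or still open speak of the compounds shown alone.

In an ADME assay on L929 cells (Mus musculus) for cytotoxicity, read by resazurin assay, with a stated time of 48 h (a lower number here means that less compound is tolerated, a higher number that more compound is tolerated), compound 1 `C=Cn1c2ccc([N+](=O)[O-])cc2c(=O)n1Cc1ccccc1` gives 160000 nM and compound 2 `C=CCn1c2ccc([N+](=O)[O-])cc2c(=O)n1Cc1ccccc1` gives 192000 nM. Compound 3 `O=c1c2cc([N+](=O)[O-])ccc2n(CCCBr)n1Cc1ccccc1` gives 25200 nM, the lowest of the three numbers. Compound 4 `N#CCn1c2ccc([N+](=O)[O-])cc2c(=O)n1Cc1ccccc1` has not yet been measured and differs from compound 3 in one place: cyano in place of 2-bromoethyl on a saturated chain carbon bound to an aromatic nitrogen. This difference can also be read as 3-bromopropyl to cyanomethyl.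

Within the data shown here, three measured steps bear on this change. Exchanging vinyl for allyl made no difference beyond the scatter, with a 1.2-fold higher number from compound 1 to compound 2 (0.08 log units; within the scatter). The two steps that introduce the bromine-bearing chain are both modest, at a 6.3-fold lower number from compound 1 to compound 3 (0.80 log units; beyond the scatter) and a 7.6-fold lower number from compound 2 to compound 3 (0.88 log units; beyond the scatter). Among the measured compounds shown here, no measured compound carries a cyano group, so the expectation rests on a single bromine-bearing compound and two compounds without bromine. Compound 4 is therefore expected to lie closer to compound 1 and compound 2 than to compound 3, perhaps somewhat short of them. The expected change is a 4.8-fold higher number from compound 3 to compound 4 (0.68 log units; beyond the scatter), a modest rise beyond the scatter. For compound 4 the estimated value is 120000 nM, with an expected range of 40000 nM to 300000 nM.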

Compound 4, concentration lethal to 50% of the cells: > 256000 nM
Compound 4 ended at the assay's limit; the forecaster's own chance of this, stated with the estimate: 10%; at least 2.1-fold (0.32 log units) between middle value and limit.
By their numbers in this assay, from the lowest: compound 3; then compounds 1 and 2 (each within the scatter of the next). At a limit, above all of these: compound 4.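

In this assay, the change from 3-bromopropyl to cyanomethyl gives an at least 10-fold higher number from compound 3 to compound 4 (1.00 log units; beyond the scatter), an at least modest step, so a nitrile-bearing group on this aromatic nitrogen does not share the low number of compound 3. Among these compounds, compound 4 is the one compound here that gives a limit of the assay and not a number: the limit of > 256000 nM in this assay, at which 1 of the 4 values shown sits. Its floors against the two compounds without bromine, an at least 1.6-fold higher number from compound 1 to compound 4 (0.20 log units; that floor lies within the scatter) and an at least 1.3-fold higher number from compound 2 to compound 4 (0.12 log units; that floor lies within the scatter), do not by themselves separate it from them, but among these four compounds the bromine-bearing chain alone gives a low number, and none goes against that.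

On these data alone, how far compound 4 lies past the limit stays open, and with it whether its number truly differs from those of compound 1 and compound 2. As far as these compounds go, it also stays open whether the low number of compound 3 goes with the bromine or with the chain that carries it, a question that a plain propyl chain, a 3-chloropropyl group or a 3-aminopropyl group on the aromatic nitrogen would address.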